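Urea analogue of two inactive amides

This account rests on a few compounds, and the source may have more. Where it says the series, first, only, none or still open, it means among the compounds named here.

Compound 1 `Cc1ccc(NC(=O)c2cc(Cl)cc(C(F)(F)F)c2)cc1OC1CCN(C(=O)c2cccnc2)CC1` and compound 2 `Cc1ccc(NC(=O)c2cnc3ccccc3c2)cc1OC1CCN(C(=O)c2cccnc2)CC1` have been measured; compound 3 `Cc1ccc(NC(=O)Nc2ccc(Cl)c(C(F)(F)F)c2)cc1OC1CCN(C(=O)c2cccnc2)CC1` has not.

In an ADME assay on BaF3 cells (Mus musculus) for antiproliferative activity (a higher number here means a weaker inhibitor of growth, a lower number a stronger inhibitor of growth), compound 1 gives > 10000 nM, which is a limit of the assay and not a number. In this assay compound 2 likewise gives > 10000 nM, again a limit. The step that the two limits leave unreadable from compound 1 to compound 2 therefore cannot be sized, and compound 2 stands only at the limit of > 10000 nM in this assay, at which 2 of the 2 values shown sit. Compound 3 differs by (4-chloro-3-(trifluoromethyl)phenyl)amino in place of quinolin-3-yl on a carbonyl carbon. With no readable step to build on, compound 3 is expected to remain near that limit in this assay, an estimated step that the limit leaves unreadable from compound 2 to compound 3. Compound 3 is estimated at 12000 nM, ranging from 3000 nM to 50000 nM.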

Compound 3, concentration for 50% growth inhibition: 3300 nM
For compound 3 the middle estimate is 3.6-fold (0.56 log units) above the measured one, within the range that was stated.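

At the carbonyl carbon, the (4-chloro-3-(trifluoromethyl)phenyl)amino group gives the first readable value: in this assay compound 3 gives 3300 nM. This replacement gives an at least 3.0-fold lower number from compound 2 to compound 3 (0.48 log units; beyond the scatter), and it also gives an at least 3.0-fold lower number from compound 1 to compound 3 (0.48 log units; beyond the scatter). Neither step has a fixed size, and the step between the other two compounds cannot be read, as their values are limits: the limit of > 10000 nM in this assay, at which 2 of the 3 values shown sit.

The compounds shown do not separate the part played by the added amino link from that of the chloro and trifluoromethyl placement on the ring. On these data alone, how a morpholine on the same carbonyl carbon would compare also stays open.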